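The source may hold more compounds than are shown below. What is called first, only, known or untested is meant among the compounds shown, and "the series" means these compounds.

Within the data shown here, in a functional assay on HUVEC cells (Homo sapiens), read by fluorescence and microscopy, with a stated time of 6 h, tested at 10 uM (a lower number here means a stronger effect, a higher number a weaker effect of the compound at the concentration tested), compound 1 `N#Cc1c(Nc2ccccc2)sc2ccccc12` gives 81%, while compound 2 `N#Cc1c(Nc2ccc(Cl)cc2)sc2ccccc12` gives 45%, the lowest of the two numbers, and the only measured step is a number 36 percentage points lower from compound 1 to compound 2 (beyond the scatter). Compound 3 `N#Cc1c(Nc2ccc(C(F)(F)F)cc2)sc2ccccc12` differs from compound 2 by trifluoromethyl in place of chloro on an aromatic carbon. That single measured step, a large fall when chloro replaced hydrogen on the aromatic carbon, does not directly cover swapping chloro for trifluoromethyl at the same place, so in this assay only a modest step is expected, if anything slightly downward. The expected step is a number 5 percentage points lower from compound 2 to compound 3 (within the scatter). Compound 3 is therefore estimated at 40%, within 20% to 65%.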

Compound 3, a percentage reported as activity, at one concentration (the size of the read-out at that concentration, not a potency): 24%
The estimate for compound 3 lay 16 percentage points above the measured number; the measured number falls inside the stated range.
By their numbers in this assay, from the lowest: compound 3; then compound 2; then compound 1.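

In this assay, the aromatic carbon para to a large group still responds once chloro is in place: trifluoromethyl brings a number 21 percentage points lower from compound 2 to compound 3 (beyond the scatter), so chloro did not exhaust what a change here can do. Measured against hydrogen at the same place, trifluoromethyl gives a number 57 percentage points lower from compound 1 to compound 3 (beyond the scatter) and is the lowest of the three compounds. Nothing available explains why trifluoromethyl goes further than chloro. On these data alone, how an amine or a carboxylic acid would behave at this place remains open. So does whether trifluoromethyl would act similarly elsewhere on this ring.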